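This account rests on a few compounds, and the source may have more. Where it says the series, first, only, none or still open, it means among the compounds named here.

Compound 1 `Cc1ccc(C)c(NC(=O)CSc2nnc(-c3ccoc3C)n2Cc2ccco2)c1` gives 398 nM in a functional assay on CHO cells for antagonist activity at Orexin receptor type 2 (Homo sapiens), read by FLIPR and calcium flux; a higher number here means a weaker inhibitor, a lower number a stronger inhibitor. Compound 2 `Cc1cccc(C)c1NC(=O)CSc1nnc(-c2ccoc2C)n1Cc1ccco1` reaches only the limit > 15800 nM in this assay, which is a limit and not a number. Compound 3 `COc1ccccc1NC(=O)CSc1nnc(-c2ccoc2C)n1Cc1ccco1` gives 501 nM in this assay.

Among the numbers at hand, compound 3 and compound 1 sit within the scatter of each other, the step being a 1.3-fold higher number from compound 1 to compound 3 (0.10 log units; within the scatter), so no order between them can be read. Compound 2 stands apart: the step of an at least 39-fold higher number from compound 1 to compound 2 (1.59 log units; beyond the scatter) and the step of an at least 31-fold lower number from compound 2 to compound 3 (1.49 log units; beyond the scatter) are both large, and both end at the limit of > 15800 nM in this assay, at which 1 of the 3 values shown sits.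

Compound 4 `Cc1occc1-c1nnc(SCC(=O)Nc2ccc(N(C)C)cc2)n1Cc1ccco1` is not yet measured. It differs from compound 3 by 4-(dimethylamino)phenyl in place of 2-methoxyphenyl on an amide-type nitrogen. All three measured steps change the aryl group on the same amide-type nitrogen. Two of them, with 2,6-dimethylphenyl, were large; the one between 2,5-dimethylphenyl and 2-methoxyphenyl stayed within the scatter. The 4-(dimethylamino)phenyl group matches none of these, so a step no larger than the scatter, or a modest weakening, is expected for compound 4, written as a 1.6-fold higher number from compound 3 to compound 4 (0.20 log units; within the scatter). Compound 4 is therefore estimated at 800 nM in this assay, with a range from 250 nM to 4000 nM.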

Compound 4, inhibition constant: 158 nM
Compound 4: the middle estimate sits 5.1-fold (0.70 log units) above what was measured; measured number outside the range, below it.
By their numbers in this assay, from the lowest: compound 4; then compounds 1 and 3 (each within the scatter of the next). At a limit, above all of these: compound 2.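

On the amide-type nitrogen, 4-(dimethylamino)phenyl is the first aryl group shown that separates from both compound 1 and compound 3 towards a stronger inhibitor in this assay, with a 3.2-fold lower number from compound 3 to compound 4 (0.50 log units; beyond the scatter) and a 2.5-fold lower number from compound 1 to compound 4 (0.40 log units; beyond the scatter). Among the compounds shown here, until now, the only steps beyond the scatter at this position involved 2,6-dimethylphenyl, whereas the change in compound 4 shows that the same position can also move the number modestly downwards from the level shared by compound 1 and compound 3. The large step of an at least 100-fold lower number from compound 2 to compound 4 (2.00 log units; beyond the scatter) starts from a limit and not a number, so its true size stays unknown: the limit of > 15800 nM in this assay, at which 1 of the 4 values shown sits.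

The compounds shown do not separate the effect of the dimethylamino group itself from that of its place on the ring, which leaves open how an unsubstituted phenyl, a 4-methoxyphenyl or a 3-(dimethylamino)phenyl would compare on this nitrogen. They also leave open whether a primary amine, a morpholine or a carboxylic acid in place of the dimethylamino group would keep the number of compound 4.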